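The compounds below may be only part of what the source reports. "The series", "measured", "known", "first", "only" and "open" are said of these compounds alone.

Notes on oral exposure in an ADME assay on the whole organism (lung, Mus musculus) for pharmacokinetics, read by LC-MS, at a dose of 30 mg/kg by the oral route; a higher number here means more compound in the circulation at the dose given, a lower number less compound in the circulation.

Measured so far:
- compound 2, `NCc1cc(Oc2cccc(C(=O)NCCn3cnnn3)c2)nc(C(F)(F)F)c1`: 3460 nM
- compound 3, `NCc1cc(O[C@H]2CCCN(C(=O)Nc3ccccc3)C2)nc(C(F)(F)F)c1`: 30000 nM
- compound 1, `NCc1cc(Oc2cccc(C(=O)NCc3cc4ccccc4s3)c2)nc(C(F)(F)F)c1`: "not determined" (no result reported)

Going by the values given here, only two numbers exist. Compound 2 stands at the lower of them; compound 3 sits well above it, and the gap between the two is beyond the usual scatter. Compound 1 adds nothing here, since no value was obtained for it. Among the compounds with values here, no pair of the measured compounds differs in a single place, so no step can be read directly from the data.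

Compound 4, `NCc1cc(Oc2cccc(C(=O)N3CC[C@@H](O)C3)c2)nc(C(F)(F)F)c1`, is the next entry to be measured. It differs from compound 2 by a group of 6 heavy atoms (4 carbon, 1 nitrogen, 1 oxygen; one five-membered non-aromatic ring with 1 hetero atom) in place of a group of 8 heavy atoms (3 carbon, 5 nitrogen; one five-membered aromatic ring with 4 hetero atoms), on a carbonyl carbon

The rest of the molecule is untouched. There is no measured precedent for this kind of exchange within the series, so the direction of the step rests on judgement rather than on a shown step. A modest rise is expected, with the step from compound 2 to compound 4 estimated at a 1.9-fold higher number from compound 2 to compound 4 (0.27 log units; within the scatter), not far beyond the scatter. Compound 4 is accordingly expected to give about 6500 nM, within a range of 2000 nM to 20000 nM.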

Compound 4, maximal plasma concentration: 9130 nM
For compound 4 the middle estimate is 1.4-fold (0.15 log units) below the measured one; the measured number falls inside the stated range.
By their numbers in this assay, from the lowest: compound 2; then compound 4; then compound 3.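

In this assay, going by these compounds alone, putting 3-hydroxypyrrolidin-1-yl on the carbonyl carbon in place of the group of 8 heavy atoms with its five-membered aromatic ring gives a 2.6-fold higher number from compound 2 to compound 4 (0.42 log units; beyond the scatter) and is the first step that can be read directly. With the rest of the molecule untouched, a change at this one place is enough to move maximal plasma concentration beyond the scatter, and here the move is upward, though the size of the step is modest. Nothing measured bears on why the number moves.

Still open, going by these compounds, is whether the step belongs to the hydroxyl group, to the non-aromatic ring itself or to the defined stereocentre, which a plain pyrrolidin-1-yl group or the opposite stereoisomer on the same carbonyl carbon would begin to separate. Also open, on these data alone, are how a morpholin-4-yl group or a longer chain ending in a carboxylic acid would stand against compound 2 at this place, and whether this single step would hold if other parts of the shared core were changed.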